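Bulk at the imidazole side-chain end: compound 3 to compound 4

This account rests on a few compounds, and the source may have more. Where it says the series, first, only, none or still open, it means among the compounds named here.

Measured compounds:
compound 1 `O=C(O)c1ccccc1-c1ccc(CCc2ncc(CCC3CCCCC3)[nH]2)cc1`: 642 nM
compound 2 `CCCCc1cnc(C(CCCO)Cc2ccc(-c3ccccc3C(=O)O)cc2)[nH]1`: 1900 nM
compound 3 `CCCCc1cnc(CCc2ccc(-c3ccccc3C(=O)O)cc2)[nH]1`: 2710 nM

In an in vitro functional assay on cells for agonist activity at Bombesin receptor subtype-3 (Homo sapiens), read by luminescence and calcium flux (on this read-out lower numbers stand for an effect already at smaller amounts and higher numbers for an effect only at larger amounts of compound), compound 3 gives the highest of the three numbers. Its nearest neighbour is compound 2, separated by a 1.4-fold higher number from compound 2 to compound 3 (0.15 log units; within the scatter), which says nothing about order. Compound 1 is furthest, separated by a 4.2-fold higher number from compound 1 to compound 3 (0.63 log units; beyond the scatter), a modest step that falls beyond the scatter.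

Compound 4 `CC(C)(C)Cc1cnc(CCc2ccc(-c3ccccc3C(=O)O)cc2)[nH]1` differs from compound 3 in one place: tert-butyl in place of propyl on a saturated chain carbon bound to an aromatic carbon

Within the data shown here, the step that bears on this change is the one between compound 1 and compound 3, a 4.2-fold higher number from compound 1 to compound 3 (0.63 log units; beyond the scatter), since it also alters the end of the same chain on the shared core; there, the larger group stood with the lower number. The step from compound 2 to compound 3 concerns a different carbon and does not inform the change. Among the measured compounds shown here, no measured pair shows exactly a branched group at this position, so the expectation rests on analogy alone.

Compound 4 is therefore expected to give a somewhat lower number than compound 3, an estimated step of a 1.8-fold lower number from compound 3 to compound 4 (0.26 log units; within the scatter), small enough that it may stay within the scatter. The estimate for compound 4 is 1500 nM, with a range from 600 nM to 4000 nM.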

Compound 4, half-maximal effective concentration: 106 nM
Estimate against measurement, compound 4: 14-fold (1.15 log units) above; measured number below the stated range.
By their numbers in this assay, from the lowest: compound 4; then compound 1; then compounds 2 and 3 (each within the scatter of the next).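

In this assay, among these compounds, tert-butyl in place of propyl on a saturated chain carbon bound to an aromatic carbon, the same difference as butyl to neopentyl, gives a 26-fold lower number from compound 3 to compound 4 (1.41 log units; beyond the scatter), so a small change in this group can move the number far more than the earlier compounds suggested. Group size alone does not order these compounds: with tert-butyl in place of the larger cyclohexylmethyl there is a 6.1-fold lower number from compound 1 to compound 4 (0.78 log units; beyond the scatter), and compound 1 goes against the earlier reading that the larger group stands with the lower number. Nothing measured here accounts for the effect of the tert-butyl group.

As far as these compounds go, it remains open whether isopropyl or cyclobutyl in place of tert-butyl would keep a number near that of compound 4. Also open, from the compounds shown here alone, is whether adding the 3-hydroxypropyl group of compound 2 to compound 4 would change its number.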